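Replacing 4-acetylphenyl with ethyl on the shared core

The compounds below may be only part of what the source reports. "The series", "measured", "known", "first", "only" and "open" are said of these compounds alone.

Within the data shown here, in a functional assay on L1210 cells (Mus musculus) for antiproliferative activity, read by cell counting, with a stated time of 96 h (on this read-out higher numbers stand for weaker inhibition and lower numbers for stronger inhibition), compound 1 `CC(=O)c1ccc(Oc2ccccc2NC(C)=C2C(=O)CC(c3ccccc3)CC2=O)cc1` gives 190 nM and holds the higher of the two numbers so far. Compound 2 `COc1ccc(Oc2ccccc2NC(C)=C2C(=O)CC(c3ccccc3)CC2=O)cc1OC` gives 65 nM in the same read-out, and the measured step of a 2.9-fold lower number from compound 1 to compound 2 (0.47 log units; beyond the scatter) lies beyond the scatter and is modest. Compound 3 `CCOc1ccccc1NC(C)=C1C(=O)CC(c2ccccc2)CC1=O` is still unmeasured, and its difference is ethyl in place of 4-acetylphenyl on an oxygen on an aromatic ring which reads 4-acetylphenoxy to ethoxy. Among the measured compounds shown here, that single measured step keeps an aromatic ring on the oxygen, so no measured compound shows what losing the ring does. On this slim basis, a modest move toward a higher number is expected in this assay with real doubt about its direction. The expected step is a 2.1-fold higher number from compound 1 to compound 3 (0.32 log units; beyond the scatter) and this is only an estimate. For compound 3 the estimated value is 400 nM with an expected range from 100 nM to 1500 nM as the upper end.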

Compound 3, half-maximal inhibitory concentration: 190 nM
For compound 3 the middle estimate is 2.1-fold (0.32 log units) above the measured one; measured number inside the range.
By their numbers in this assay, from the lowest: compound 2; then compounds 1 and 3 (each within the scatter of the next).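

In this assay, an aromatic ring on this oxygen proves dispensable at the level of compound 1: ethyl in place of 4-acetylphenyl, a much smaller group with no ring, gives no change at the digits printed from compound 1 to compound 3 (within the scatter). The same ethyl group set against 3,4-dimethoxyphenyl gives a 2.9-fold higher number from compound 2 to compound 3 (0.47 log units; beyond the scatter), so the ring alone does not decide the number, and only the ring bearing the two methoxy groups stands apart among these three compounds. Nothing given here accounts for this ordering.

The compounds shown leave open whether a longer chain such as butyl, or an amine at the end of the ethyl chain, would shift the number on this oxygen. They also leave open whether a phenyl ring carrying a single methoxy group would match compound 2 or fall in with compound 1 and compound 3.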